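A few compounds are considered here, and "the series" means these few. Any claim that something is new, unique, unknown or untested is made for them only; others in the source may bear on it.

In an ADME assay on HCT-116 cells (Homo sapiens) for antiproliferative activity (a lower number here means a stronger inhibitor, a higher number a weaker inhibitor), compound 1 `CCc1ccc(OC)c(COc2ccc(Cl)c(C)c2)c1` gives 43000 nM. Compound 2 `COc1ccc(C#N)cc1COc1ccc(Cl)c(C)c1` is reported only as a limit, > 50000 nM. Compound 3 `COc1ccc(C(N)=O)cc1/C=C/c1ccc(C(C)(C)C)cc1` gives 20000 nM, the lower of the two actual numbers, and its gap to compound 1 lies beyond the usual scatter.

The next compound, compound 4 `COc1ccc(C(N)=O)cc1/C=C/c1ccc([N+](=O)[O-])cc1`, has nitro in place of tert-butyl on an aromatic carbon, para to a large group (nitro in place of tert-butyl on an aromatic carbon). Among the measured compounds shown here, only one measured step offers any guide, cyano in place of ethyl on an aromatic carbon, which gave an at least 1.1-fold higher number from compound 1 to compound 2 (0.06 log units; that floor lies within the scatter). That step is only a floor, and it belongs to the core of compound 1, not the core of compound 3, so it is weak support for any forecast. A modest move toward a higher number in this assay is therefore expected, with no firm claim that it will clear the scatter. The estimated change is a 1.3-fold higher number from compound 3 to compound 4 (0.10 log units; within the scatter). For compound 4 the expected value is 25000 nM, with an estimated range from 6000 nM to 60000 nM.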

Compound 4, half-maximal inhibitory concentration: 22000 nM
Compound 4: the middle estimate sits 1.1-fold (0.06 log units) above what was measured; low and high end bracket the measured number.
By their numbers in this assay, from the lowest: compounds 3, 4 and 1 (each within the scatter of the next, the first and the last beyond it). At a limit, above all of these: compound 2.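

In this assay, putting nitro in place of tert-butyl on this aromatic carbon, para to a large group, gives a 1.1-fold higher number from compound 3 to compound 4 (0.04 log units; within the scatter). Unlike the earlier step, an at least 1.1-fold higher number from compound 1 to compound 2 (0.06 log units; that floor lies within the scatter), which rests on a limit and so offers only a floor, this one compares two actual numbers, and it shows that on the core of compound 3 exchanging a group of carbon only for one of nitrogen and oxygen, with hydrogen-bond acceptors, leaves the number within the scatter. No measurement shown here bears on why these two groups read alike.

The compounds shown leave open whether an amine or a carboxylic acid at this position would move the number beyond the scatter. They also leave open whether nitro in place of tert-butyl would read the same on the core of compound 1.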